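Swapping the ring oxygen for sulfur in a dioxoheterocycle

The source may hold more compounds than are shown below. What is called first, only, known or untested is meant among the compounds shown, and "the series" means these compounds.

Measured so far:
compound 1 `CC(C)[C@@H](C[C@H]1SC(=O)NC1=O)c1ccc(-c2ccc3cccc(F)c3c2)[nH]c1=O` gives 12200 nM
compound 2 `CC(C)[C@H](C[C@H]1OC(=O)NC1=O)c1ccc(-c2ccc3cccc(F)c3c2)[nH]c1=O` gives 24400 nM
compound 3 `CC(C)[C@H](C[C@@H]1OC(=O)NC1=O)c1ccc(-c2ccc3cccc(F)c3c2)[nH]c1=O` gives 25100 nM

In a physicochemical assay for solubility, measured as kinetic solubility, at pH 2 (on this read-out higher numbers stand for higher solubility and lower numbers for lower solubility), compound 3 stands highest of the three numbers, though compound 2 sits within the scatter of it; only compound 1 lies clearly lower. Compound 4 `CC(C)[C@H](C[C@H]1SC(=O)NC1=O)c1ccc(-c2ccc3cccc(F)c3c2)[nH]c1=O` differs from compound 3 by 2,4-dioxo-1,3-thiazolidin-5-yl in place of 2,4-dioxo-1,3-oxazolidin-5-yl on a saturated chain carbon, two bonds along the chain from an aromatic carbon. Among the measured compounds shown here, no measured step isolates this change. The step of a 1.0-fold higher number from compound 2 to compound 3 (0.01 log units; within the scatter) concerns only the ring stereocentre, as the fact that compounds 2 and 3 differ only in the configuration as drawn shows, so it says nothing about the heteroatom. Compound 1, which also carries the thiazolidine ring but differs further in the chain stereocentre, gives a lower number than compound 3. A modest downward step is therefore expected, a 1.7-fold lower number from compound 3 to compound 4 (0.22 log units; within the scatter). Compound 4 is estimated at 15000 nM, in the range 7000 nM to 30000 nM.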

Compound 4, solubility: 4900 nM
Compound 4: the middle estimate sits 3.1-fold (0.49 log units) above what was measured; measured number below the stated range.
By their numbers in this assay, from the lowest: compound 4; then compounds 1, 2 and 3 (each within the scatter of the next, the first and the last beyond it).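

In this assay, 2,4-dioxo-1,3-thiazolidin-5-yl in place of 2,4-dioxo-1,3-oxazolidin-5-yl on a saturated chain carbon gives a clear drop: a 5.1-fold lower number from compound 3 to compound 4 (0.71 log units; beyond the scatter) and a 5.0-fold lower number from compound 2 to compound 4 (0.70 log units; beyond the scatter). The chain stereocentre also counts here, unlike the ring stereocentre with its a 1.0-fold higher number from compound 2 to compound 3 (0.01 log units; within the scatter), since a 2.5-fold lower number from compound 1 to compound 4 (0.40 log units; beyond the scatter) is beyond the scatter and can be read as a stereochemical step alone: the fact that compounds 1 and 4 differ only in the configuration as drawn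

Still open, from the compounds shown here alone, is whether the chain stereocentre counts in the same way with 2,4-dioxo-1,3-oxazolidin-5-yl. Also open, going by these compounds, is how a carboxylic acid or an amine on that chain carbon would read.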